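The compounds below may be only part of what the source reports. "The series", "measured", "known", "first", "only" and "open" are said of these compounds alone.

Measured so far in a functional assay on CHO cells for agonist activity at Alpha-2C adrenergic receptor (Homo sapiens); on this read-out lower numbers stand for smaller maximal responses and higher numbers for larger maximal responses:
compound 1, `CS(=O)(=O)c1ccc(F)cc1NCC1=NCCN1`, gives 91%
compound 2, `Cc1ccc(S(C)(=O)=O)c(NCC2=NCCN2)c1`, gives 76%

Compound 2 stands lowest of the two numbers in this assay; its nearest neighbour is compound 1, whose value is higher by a step that goes beyond the usual scatter. Within the data shown here, the only step measured so far, a number 15 percentage points lower from compound 1 to compound 2 (beyond the scatter), shows what happens when methyl takes the place of fluoro on an aromatic carbon of the shared core.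

Compound 3, `CS(=O)(=O)c1ccc(Cl)cc1NCC1=NCCN1`, has not yet been measured. It differs from compound 2 in one place: chloro in place of methyl on an aromatic carbon. The change sits on an aromatic carbon of a six-membered aromatic ring of carbon only, para to a methylsulfonyl group. Among the measured compounds shown here, no measured step covers chloro directly, so the step from compound 1 to compound 2 is the only guide, and it bears on this change only by showing that the same position tolerates a change of group with a modest shift. For compound 3 a small rise toward compound 1 is expected, a number 8 percentage points higher from compound 2 to compound 3 (within the scatter), though a flat result would not be surprising. The estimate for compound 3 in this assay is 84%, with a range from 68% to 98%.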

Compound 3, largest response reached (reported as maximum), in percent of the reference or control that the assay uses: 81%
Compound 3: middle estimate off by 3 percentage points, on the high side, within the range that was stated.
By their numbers in this assay, from the lowest: compounds 2, 3 and 1 (each within the scatter of the next, the first and the last beyond it).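

In this assay, putting chloro on this aromatic carbon, para to a methylsulfonyl group, gives a number 5 percentage points higher from compound 2 to compound 3 (within the scatter) and, measured against the fluoro compound, a number 10 percentage points lower from compound 1 to compound 3 (within the scatter) on the same read-out. Fluoro and methyl at this place are separated by a number 15 percentage points lower from compound 1 to compound 2 (beyond the scatter), whereas chloro cannot be told apart from either of them, so the new compound fills the gap without a clear difference from either end of it. Among these compounds, no measurement in hand gives a reason for these numbers or shows what lies behind the one step that exceeds the scatter.

Going by these compounds, three small groups, each of a single atom or a methyl, are too few to show how far this place can be changed, and the response with a larger or very different group, such as an amine, a carboxylic acid or a longer chain, remains open. Also open, on these data alone, is whether the same swaps would give similar steps at another aromatic carbon of the shared core, or with the methylsulfonyl group replaced.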